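Isoflavone ethers on gastric carcinoma cells: working notes

The source may report more compounds than this note shows. Statements on the series, on what has been measured and on what is new or still open speak of the compounds shown alone.

Measured compounds:
compound 1 `CCN1CCN(C(=S)SCCCOc2ccc3c(=O)c(-c4ccc(OC)cc4)coc3c2)CC1`, 54000 nM
compound 2 `COc1ccc(-c2coc3cc(OCCCSC(=S)N4CCOCC4)ccc3c2=O)cc1`, 49600 nM
compound 3 `COc1ccc(-c2coc3cc(OCCCSC(=S)N4CCN(C)CC4)ccc3c2=O)cc1`, 21900 nM

In a functional assay on MGC-803 cells (Homo sapiens) for inhibition, read by MTT assay, with a stated time of 48 h (a lower number here means a stronger inhibitor, a higher number a weaker inhibitor), compound 3 gives the lowest of the three numbers. Its nearest neighbour is compound 2 (a 2.3-fold lower number from compound 2 to compound 3 (0.36 log units; beyond the scatter)), and the furthest is compound 1 (a 2.5-fold lower number from compound 1 to compound 3 (0.39 log units; beyond the scatter)). Compound 1 and compound 2 sit within the scatter of each other (a 1.1-fold lower number from compound 1 to compound 2 (0.04 log units; within the scatter)).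

Compound 4 `COc1ccc(-c2coc3cc(OCCCCBr)ccc3c2=O)cc1` is not yet measured. It differs from compound 3 in one place: a group of 2 heavy atoms (1 carbon, 1 bromine; no ring) in place of a group of 10 heavy atoms (6 carbon, 2 nitrogen, 2 sulfur; one six-membered non-aromatic ring with 2 hetero atoms), on a saturated chain carbon, three bonds along the chain from an oxygen on an aromatic ring. Going by the values given here, all three measured steps exchange one ring amine on the thiocarbonyl carbon for another; none removes that whole group or introduces a bromine, so no measured step bears directly on this change. The amine exchanges moved the number only modestly, and the whole dithiocarbamate portion is now gone. The expected step is therefore set near zero, with a wide range, a 1.8-fold higher number from compound 3 to compound 4 (0.26 log units; within the scatter). Compound 4 is estimated at 40000 nM, between 15000 nM and 120000 nM.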

Compound 4, half-maximal inhibitory concentration: 52700 nM
Beside the measured number, compound 4's estimate is 1.3-fold (0.12 log units) below it; the measured number falls inside the stated range.
By their numbers in this assay, from the lowest: compound 3; then compounds 2, 4 and 1 (each within the scatter of the next).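

At this chain carbon, bromomethyl in place of the group carrying the 4-methylpiperazin-1-yl ring gives a modest step in this assay (a 2.4-fold higher number from compound 3 to compound 4 (0.38 log units; beyond the scatter)). The same kind of exchange starting from the morpholin-4-yl and 4-ethylpiperazin-1-yl compounds gives no change beyond the scatter (a 1.1-fold higher number from compound 2 to compound 4 (0.03 log units; within the scatter)) and (a 1.0-fold lower number from compound 1 to compound 4 (0.01 log units; within the scatter)), so the thiocarbonyl group as such brings no gain here: of the three compounds carrying it, only compound 3 stands apart from compound 4, while compound 1 and compound 2 go against any general gain. No supporting data explain why the ring amine matters only in compound 3.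

On these data alone, whether a simple amine or a carboxylic acid at this chain carbon would give a number nearer compound 3 or compound 4 remains open. As far as these compounds go, the effect of a longer chain also remains open.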